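Benzothiazepine sulfone series: acylamino replacing methoxy on the aromatic ring

The compounds below may be only part of what the source reports. "The series", "measured", "known", "first", "only" and "open" are said of these compounds alone.

Compound 1 `CCCC[C@]1(CC)CS(=O)(=O)c2ccc(OC)cc2[C@@H](c2ccccc2)[C@H]1O` is the reference point. In an assay on cells for inhibition of ileal sodium/bile acid cotransporter (Homo sapiens) (a higher number here means a weaker inhibitor, a lower number a stronger inhibitor), compound 1 gives 55 nM, the lowest of the three numbers in hand. Compound 2 `CCCC[C@]1(CC)CS(=O)(=O)c2cc(O)ccc2[C@@H](c2ccccc2)[C@H]1O` gives 90 nM, within the scatter of compound 1, so no order between the two is claimed. Compound 3 `C=CCCCCCCCCOc1ccc2c(c1)S(=O)(=O)C[C@@](CC)(CCCC)[C@H](O)[C@@H]2c1ccccc1` gives 16000 nM, far above both.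

Among the compounds with values here, the single measured step, a 180-fold higher number from compound 2 to compound 3 (2.25 log units; beyond the scatter), shows that a long chain placed on the aromatic oxygen of the core raises the number sharply.

Compound 4 `CCCCCC(=O)Nc1ccc2c(c1)[C@@H](c1ccccc1)[C@@H](O)[C@](CC)(CCCC)CS2(=O)=O` differs from compound 1 in one place: (pentylcarbonyl)amino in place of methoxy on an aromatic carbon. This is not the same change as the measured step, since the entering group is shorter, carries an amide rather than an ether, and sits at the position held by the methoxy of compound 1 rather than at the oxygen of compound 2. Within the data shown here, still, the only precedent for enlarging a substituent on this ring is the step from compound 2 to compound 3, and it points upward.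

The expectation for compound 4 is therefore a higher number than compound 1, by a margin smaller than that step, a 7.3-fold higher number from compound 1 to compound 4 (0.86 log units; beyond the scatter). The estimated value for compound 4 is 400 nM, with a range of 80 nM to 2500 nM.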

Compound 4, half-maximal inhibitory concentration: 300 nM
Compound 4: middle estimate off by 1.3-fold (0.12 log units), on the high side, within the range that was stated.
By their numbers in this assay, from the lowest: compounds 1 and 2 (each within the scatter of the next); then compound 4; then compound 3.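

Within the data shown here, at the aromatic carbon that holds the methoxy of compound 1, meta to a fused ring and para to a fused ring, (pentylcarbonyl)amino in its place gives a 5.5-fold higher number from compound 1 to compound 4 (0.74 log units; beyond the scatter) in this assay, the first measured change at this position. Compound 4 stays at 300 nM, so this larger amide-linked group carries a modest rise here, well short of a 180-fold higher number from compound 2 to compound 3 (2.25 log units; beyond the scatter), though that step involves a different group at a different place on the ring and is no direct measure of chain length. Nothing in hand accounts for the rise.

The compounds shown do not separate the part played by the amide link from that played by the chain: acetylamino, with its shorter chain, and hexyloxy, with an ether link, would each bear on this at the same aromatic carbon. Also open, from the compounds shown here alone, is how the number responds to a free amine or a carboxylic acid at the end of the chain, and whether a longer chain on the amide raises it further.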